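A few compounds are considered here, and "the series" means these few. Any claim that something is new, unique, unknown or untested is made for them only; others in the source may bear on it.

The series shares one core, carried by compound 3 `COc1cc(OC)c(/C=C/S(=O)(=O)Cc2ccc([N+](=O)[O-])cc2)c(OC)c1`, compound 2 `COc1cc(OC)c(/C=C/S(=O)(=O)Cc2ccc(OC)c(OC)c2OC)c(OC)c1`, compound 1 `COc1cc(OC)c(/C=C/S(=O)(=O)Cc2cc(OC)c(OC)c(OC)c2)c(OC)c1` and the still unmeasured compound 4 `COc1cc(OC)c(/C=C/S(=O)(=O)Cc2ccc(O)cc2)c(OC)c1`. In a functional assay on DU-145 cells (Homo sapiens) for antiproliferative activity, read by trypan blue exclusion (a lower number here means a stronger inhibitor, a higher number a weaker inhibitor), compound 3 gives 15000 nM. Compound 2 gives 12500 nM in this assay. For compound 1 only a limit is recorded in this assay, namely > 20000 nM, the limit described by the limit of > 20000 nM in this assay, at which 1 of the 3 values shown sits. Going by the values given here, of the two numbers, the one for compound 3 is nominally the higher, yet it lies within the scatter of the number for compound 2, so the two compounds are not distinguished, and beyond them there is only the limit of compound 1 to place compound 3 against.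

The change from compound 3 to compound 4 is hydroxy in place of nitro on an aromatic carbon. Among the compounds with values here, no step between two measured compounds covers this exchange, and no measured property of either group is available, so neither direction nor size can be read off the data. Since all three measured compounds sit at weak potency, the expectation for compound 4 is a step of a 1.3-fold lower number from compound 3 to compound 4 (0.10 log units; within the scatter), that is, nothing beyond the scatter. Compound 4 is accordingly estimated at 12000 nM in this assay, with a range from 4000 nM to 30000 nM.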

Compound 4, half-maximal inhibitory concentration: 7500 nM
For compound 4 the middle estimate is 1.6-fold (0.20 log units) above the measured one; the range from low to high includes it.
By their numbers in this assay, from the lowest: compounds 4, 2 and 3 (each within the scatter of the next). At a limit, above all of these: compound 1.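

In this assay, going by these compounds alone, the exchange of 4-nitrophenyl for 4-hydroxyphenyl gives the first reading of any change at this place, on an aromatic carbon para to a large group, and it amounts to a 2.0-fold lower number from compound 3 to compound 4 (0.30 log units; within the scatter), so compound 3 and compound 4 are not distinguished. The exchange replaces a larger group that has no hydrogen-bond donor with a single oxygen that carries one, and this substantial change in the group does not move the number beyond the scatter, which suggests that this place can accept quite different groups without a clear loss or gain in this assay. The data give no measured property of either group that bears on this step.

An amine or a carboxylic acid at this same place is not among the compounds shown, so it stays open whether any group here can produce a step beyond the scatter. Within the data shown here, with only a single exchange at this place, it also remains open whether the same exchange would read alike on a core with a different substitution pattern on its other ring.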